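Pyridine amidrazone thiosemicarbazides: cytotoxicity notes on A-431

The source may report more compounds than this note shows. Statements on the series, on what has been measured and on what is new or still open speak of the compounds shown alone.

Measured compounds:
- compound 1, `Cc1ccnc(/C(N)=N/NC(=S)N2CCCCCC2)c1`, 8000 nM
- compound 2, `N/C(=N\NC(=S)N1CCOCC1)c1ccc(F)cn1`, 4000 nM
- compound 3, `N/C(=N\NC(=S)N1CCN(c2ccccn2)CC1)c1ccc(F)cn1`, 13400 nM

All three were read in a functional assay on A-431 cells (Homo sapiens) for cytotoxicity, read by MTT assay, with a stated time of 72 h; on this read-out lower numbers stand for stronger inhibition and higher numbers for weaker inhibition. Compound 3 gives the highest of the three numbers. Its nearest neighbour on this read-out is compound 1, whose number is lower but within the usual scatter, so the two cannot be told apart. Compound 2 sits furthest away, with a number low enough to lie beyond the scatter; compound 2 is therefore the one of the three that separates from compound 3 on this assay. For the measured compounds named here, no pair of measured compounds differs in a single place, so no step within the measured set can be taken as a guide.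

The next compound, compound 4, `Cc1cccc(/C(N)=N/NC(=S)N2CCN(c3ccccn3)CC2)n1`, is built from compound 3 by one change: 6-methylpyridin-2-yl in place of 5-fluoropyridin-2-yl on a carbon with a double bond to nitrogen. The shared part of compound 3 and compound 4 is otherwise unchanged. Going by the values given here, nothing among the measured compounds isolates a change of this kind, so the expectation rests on the weak spread seen across compounds 1 to 3. The step from compound 3 to compound 4 is expected to be small, a 1.3-fold lower number from compound 3 to compound 4 (0.13 log units; within the scatter), and not beyond the scatter in either direction. Compound 4 is estimated at 10000 nM, with a range from 3500 nM to 30000 nM.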

Compound 4, half-maximal inhibitory concentration: 19600 nM
Beside the measured number, compound 4's estimate is 2.0-fold (0.29 log units) below it; measured number inside the range.
By their numbers in this assay, from the lowest: compounds 2, 1, 3 and 4 (each within the scatter of the next, the first and the last beyond it).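

In this assay, for the compounds shown here, 6-methylpyridin-2-yl in place of 5-fluoropyridin-2-yl on the carbon with a double bond to nitrogen gives a 1.5-fold higher number from compound 3 to compound 4 (0.17 log units; within the scatter), and this is the only single-place step available. With everything else in the structure unchanged, the two substituted pyridine groups cannot be told apart on this read-out, so this exchange leaves the cytotoxicity number without a change that can be read, something the unmatched compounds 1 to 3 could not show. No available evidence bears on the reason for this outcome.

One exchange on one shared scaffold leaves open whether the position responds at all, since both groups tested here are substituted pyridines of equal heavy-atom count, and whether the same exchange would read alike with the other side groups seen in compound 1 and compound 2. A phenyl ring, an unsubstituted pyridin-2-yl or a pyridine bearing a carboxylic acid or an amine at this place would test the position more widely than this close pair can.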